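The compounds below may be only part of what the source reports. "The series", "measured", "known", "first", "only" and "open" are said of these compounds alone.

Measured in a functional assay, with a stated time of 6 min; a higher number here means a weaker inhibitor, a lower number a stronger inhibitor:

compound 1 `Fc1ccccc1NCn1nc(-c2ccc3c(c2)OCCO3)oc1=S`: 6390 nM
compound 2 `Fc1cccc(NCn2nc(-c3ccc4c(c3)OCCO4)oc2=S)c1`: 6620 nM
compound 3 `S=c1oc(-c2ccc3c(c2)OCCO3)nn1CNc1ccc(Br)cc1Br`: 6410 nM

All three share one core and differ only in the aryl group on the amine nitrogen. The three numbers sit on top of each other: a 1.0-fold higher number from compound 1 to compound 2 (0.02 log units; within the scatter) and a 1.0-fold lower number from compound 2 to compound 3 (0.01 log units; within the scatter) are both within the scatter, and a 1.0-fold higher number from compound 1 to compound 3 (0.00 log units; within the scatter) likewise. Compound 2 therefore cannot be placed above or below compound 1 or compound 3; the three are indistinguishable on these data.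

Compound 4 `O=[N+]([O-])c1ccc(NCn2nc(-c3ccc4c(c3)OCCO4)oc2=S)cc1` is the next variation at the same position: 4-nitrophenyl in place of 3-fluorophenyl on an amine nitrogen. Among the compounds with values here, the steps that bear on it are the three aryl exchanges already measured, each of which left this assay unchanged, so the aryl group on the amine nitrogen appears not to move the read-out, at least across the three groups tried. A nitro group has not been tested, but with nothing in the series pointing either way, the expected step of a 1.0-fold lower number from compound 2 to compound 4 (0.01 log units; within the scatter) is none beyond the scatter. Compound 4 is estimated at 6500 nM, range 3000 nM to 14000 nM.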

Compound 4, half-maximal inhibitory concentration: 9950 nM
Compound 4: middle estimate off by 1.5-fold (0.18 log units), on the low side; the range from low to high includes it.
By their numbers in this assay, from the lowest: compounds 1, 3, 2 and 4 (each within the scatter of the next).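

In this assay the fourth aryl group on the amine nitrogen also gives no step beyond the scatter: a 1.5-fold higher number from compound 2 to compound 4 (0.18 log units; within the scatter) and a 1.6-fold higher number from compound 3 to compound 4 (0.19 log units; within the scatter) and a 1.6-fold higher number from compound 1 to compound 4 (0.19 log units; within the scatter) are all that separate it from the others. The position thus extends from halogenated phenyl groups to 4-nitrophenyl, which carries hydrogen-bond acceptors and a double bond outside the aromatic ring that 3-fluorophenyl lacks, and the read-out still does not separate the compounds. No supporting measurement bears on this result.

Whether anything at this place can separate from these four compounds stays open, since all the groups shown are substituted phenyl rings; a carboxylic acid on the phenyl ring, a saturated cyclohexyl group or a longer alkyl chain would test that. From the compounds shown here alone, the effect of changes to the shared core also remains unknown.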